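Aryl branch on the ether chain of the alpha-1 series

A few compounds are considered here, and "the series" means these few. Any claim that something is new, unique, unknown or untested is made for them only; others in the source may bear on it.

Working notes on the series. Compound 1 `COc1ccccc1NC(=O)c1ccc(OCCCN2CCN(c3ccccc3OC)CC2)cc1` carries the shared core with hydrogen on the chain carbon bound to the ring oxygen, and in an assay on Prostate gland (Oryctolagus cuniculus) for inhibition of Adrenergic receptor alpha-1 (Homo sapiens) (on this read-out lower numbers stand for tighter binding and higher numbers for weaker binding), compound 1 gives 79.4 nM. Compound 2 `COc1ccccc1N1CCN(CCCOc2ccc(C(=O)Nc3ccccc3OCCCC(=O)O)cc2)CC1` adds the carboxyalkoxy arm, and in this assay compound 2 gives 100 nM; the step of a 1.3-fold higher number from compound 1 to compound 2 (0.10 log units; within the scatter) is flat. Compound 3 `COc1ccccc1N1CCN(CCC(Oc2ccc(NC(=O)c3ccccc3OCCCC(=O)O)cc2)c2ccc(CC(C)C)cc2)CC1` carries an isobutylphenyl branch on the chain carbon together with other changes, and in this assay compound 3 gives 6310 nM. Among the three numbers compound 2 stands second highest, close to compound 1 and far below compound 3.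

Compound 4 `COc1ccc(C(CCN2CCN(c3ccccc3OC)CC2)Oc2ccc(C(=O)Nc3ccccc3OCCCC(=O)O)cc2)cc1` is the next member: 4-methoxyphenyl in place of hydrogen on a saturated chain carbon bound to an oxygen on an aromatic ring and a saturated chain carbon. For the measured compounds named here, no single-place step of this kind has been measured. Going by the values given here, the only step measured, a 1.3-fold higher number from compound 1 to compound 2 (0.10 log units; within the scatter), concerns a different position and says nothing about an aryl branch on the chain. The pair compound 2 and compound 3 shows that a branched analogue carries a much higher number, but compound 3 differs in several places at once, so its value is only a loose pointer. The step from compound 2 to compound 4 is therefore expected to raise the number, an 8.0-fold higher number from compound 2 to compound 4 (0.90 log units; beyond the scatter), with wide uncertainty. Compound 4 is expected to give 800 nM in this assay, within a range from 150 nM to 4500 nM.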

Compound 4, dissociation constant: 200 nM
Compound 4: the middle estimate sits 4.0-fold (0.60 log units) above what was measured; measured number inside the range.
By their numbers in this assay, from the lowest: compounds 1, 2 and 4 (each within the scatter of the next, the first and the last beyond it); then compound 3.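

For the compounds shown here, at this position, on a saturated chain carbon bound to an oxygen on an aromatic ring and a saturated chain carbon, the first single-place reading in this assay is a 2.0-fold higher number from compound 2 to compound 4 (0.30 log units; within the scatter) and so lies within the scatter: 4-methoxyphenyl, with its 8 heavy atoms, can stand in place of hydrogen without a step beyond the scatter. An aryl branch on this carbon therefore does not by itself go with a number as high as that of compound 3 at 6310 nM, and the changes that compound 3 carries in several places at once remain unseparated. No evidence bearing on this result is available, so the reading stays purely descriptive.

Open, going by these compounds, is what isobutylphenyl alone would give at this carbon on the core of compound 2, which would show whether the number of compound 3 goes with that branch or with its other changes. Also open, on these data alone, is how a smaller methyl group, an unsubstituted phenyl or an amine would read at the same place.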